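Fluoro to Methoxy Exchange on Indolyl Acrylonitriles in Prostate Cells

The source may hold more compounds than are shown below. What is called first, only, known or untested is meant among the compounds shown, and "the series" means these compounds.

Compound 1 `COc1ccc2[nH]cc(/C=C(\C#N)C(=O)c3c[nH]c4cc(F)ccc34)c2c1` was examined in a functional assay on PC-3 cells (Homo sapiens) for cytotoxicity, read by WST assay, with a stated time of 48 h; a lower number here means a stronger inhibitor, a higher number a weaker inhibitor. In this assay compound 1 gives > 50000 nM, which is a limit of the assay and not a number. Compound 2 `N#C/C(=C\c1cn(Cc2ccc(Cl)cc2)c2ccccc12)C(=O)c1c[nH]c2cc(F)ccc12` carries a core whose difference from the core of compound 1 is not broken down here. In this assay compound 2 gives > 50000 nM, again only a limit. Compound 3 `COc1ccc2c(C(=O)/C(C#N)=C/c3cn(Cc4ccc(Cl)cc4)c4ccccc34)c[nH]c2c1` differs from compound 2 by methoxy in place of fluoro on an aromatic carbon. In this assay compound 3 gives > 50000 nM, also a limit. For the measured compounds named here, the step from compound 2 to compound 3 is therefore a step that the two limits leave unreadable from compound 2 to compound 3; the only evidence on it is the limit of > 50000 nM in this assay, at which 3 of the 3 values shown sit.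

Compound 4 `COc1ccc2c(C(=O)/C(C#N)=C/c3c[nH]c4ccc(OC)cc34)c[nH]c2c1`, not yet measured, differs from compound 1 by the same change, (methoxy in place of fluoro on an aromatic carbon), applied this time to the core of compound 1. Compound 4 is expected to give 50000 nM, most probably reported once more as a limit, with a range from 20000 nM to 100000 nM. This estimate means a step of a number no higher from compound 1 to compound 4 (the limit leaves the size open), and it rests on the unreadable step that the two limits leave unreadable from compound 2 to compound 3 seen for the same change.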

Compound 4, half-maximal inhibitory concentration: 37100 nM
The estimate for compound 4 lay 1.3-fold (0.13 log units) above the measured number; the range from low to high includes it.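

In this assay the exchange of fluoro for methoxy on the core of compound 1 gives an at least 1.3-fold lower number from compound 1 to compound 4 (0.12 log units; that floor lies within the scatter), and compound 4, at 37100 nM, is the only compound shown with a number rather than a limit. Going by these compounds, this does not show that the change lowers the number on either core: the floor of the step lies within the scatter, its full size stays open, and the same change from compound 2 to compound 3 cannot be read. Whether the change carries from one core to another therefore cannot be judged, and the record for doing so is thin: the limit of > 50000 nM in this assay, at which 3 of the 4 values shown sit.

The compounds shown leave open whether another group on this aromatic carbon, such as an amine, a carboxylic acid or a longer alkoxy chain, would give a number well clear of the limit. They also leave open how methoxy would compare with fluoro on a core where the fluoro compound gives a number and not a limit.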